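Cytotoxicity notes: methyl on the piperidinyl ring, compound 4

This account rests on a few compounds, and the source may have more. Where it says the series, first, only, none or still open, it means among the compounds named here.

Measured so far, as half-maximal inhibitory concentration in a toxicity assay on HeLa cells (Homo sapiens) for cytotoxicity, read by MTT assay, with a stated time of 24 h; on this read-out higher numbers stand for weaker inhibition and lower numbers for stronger inhibition:
- compound 1, `CCN1CCN(C(=S)SCC(O)Cn2c([N+](=O)[O-])cnc2C)CC1`: > 5000000 nM.
- compound 2, `Cc1ncc([N+](=O)[O-])n1CC(O)CSC(=S)N1CCCC1`: 1340000 nM.
- compound 3, `Cc1ncc([N+](=O)[O-])n1CC(O)CSC(=S)N1CCCCC1`: 1400000 nM.

Compound 3 holds the highest of the two numbers shown; its nearest neighbour is compound 2, and the step of a 1.0-fold higher number from compound 2 to compound 3 (0.02 log units; within the scatter) lies within the scatter. For compound 1 the value is a limit of the assay, not a number, as noted in the limit of > 5000000 nM in this assay, at which 1 of the 3 values shown sits. From compound 1 the steps of an at least 3.7-fold lower number from compound 1 to compound 2 (0.57 log units; beyond the scatter) and an at least 3.5-fold lower number from compound 1 to compound 3 (0.55 log units; beyond the scatter) are the only ones beyond the scatter, and both concern an exchange of the whole amine on the thiocarbonyl carbon.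

Compound 4, `Cc1ncc([N+](=O)[O-])n1CC(O)CSC(=S)N1CCCC(C)C1`, differs from compound 3 by methyl in place of hydrogen on a saturated ring carbon; read one bond further out, piperidin-1-yl becomes 3-methylpiperidin-1-yl. Among the compounds with values here, no measured step touches a substituent on the saturated ring itself. The closest comparison, the ring-size change from compound 2 to compound 3, gave no step beyond the scatter, so a change of this kind is expected to give none either: the step of no change at the digits printed from compound 3 to compound 4 (within the scatter) is expected to stay within the scatter. In this assay compound 4 is therefore estimated at 1400000 nM, within 700000 nM to 2800000 nM.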

Compound 4, half-maximal inhibitory concentration: 609000 nM
Compound 4: the middle estimate sits 2.3-fold (0.36 log units) above what was measured, outside the stated range (below it).
By their numbers in this assay, from the lowest: compound 4; then compounds 2 and 3 (each within the scatter of the next). At a limit, above all of these: compound 1.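

In this assay, a substituent on the saturated ring itself shifts the number, which the change of ring size did not do, as a 1.0-fold higher number from compound 2 to compound 3 (0.02 log units; within the scatter) stayed within the scatter: methyl on a ring carbon two ring bonds from the ring nitrogen gives a 2.3-fold lower number from compound 3 to compound 4 (0.36 log units; beyond the scatter). The 3-methylpiperidin-1-yl group also separates from the pyrrolidin-1-yl group, with a 2.2-fold lower number from compound 2 to compound 4 (0.34 log units; beyond the scatter), so among the compounds shown compound 4 has the lowest number, and the amine on the thiocarbonyl carbon matters in its substitution as well as in its overall identity. Compound 1 is a limit of the assay and not a number, so the comparison with the 4-ethylpiperazin-1-yl group reads only as an at least 8.2-fold lower number from compound 1 to compound 4 (0.91 log units; beyond the scatter), and its true size stays unfixed: the limit of > 5000000 nM in this assay, at which 1 of the 4 values shown sits.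

On these data alone, with a single methyl at a single ring carbon, it remains open whether the shift follows the size of the group or something specific to methyl, for which an ethyl, a hydroxyl or a fluorine at the same carbon would be the telling cases. As far as these compounds go, it is also open whether a second methyl on the ring, or a morpholine in place of the piperidine, would carry the number further in the same direction.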